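The source may report more compounds than this note shows. Statements on the series, on what has been measured and on what is new or still open speak of the compounds shown alone.

Measured so far in a physicochemical assay for solubility; a lower number here means a less soluble compound, a higher number a more soluble compound:
- compound 1 `COc1ccc2c(c1)[nH]c1c2c2c(c3c4cccc5c4n(c13)CC(CO)C5)C(=O)NC2=O` gives 490 ug/mL
- compound 2 `O=C1NC(=O)c2c1c1c3ccccc3[nH]c1c1c2c2cccc3c2n1CC(CO)CC3` gives 1070 ug/mL
- compound 3 `O=C1NC(=O)c2c1c1c3ccccc3ccc1c1c2c2cccc3c2n1C(CO)CC3` gives 2780 ug/mL

Compound 1 stands lowest of the three numbers in this assay. Its nearest neighbour is compound 2, whose number is higher by a margin beyond the usual scatter; compound 3 stands further off still, also beyond the scatter. Among the compounds with values here, no two of the three measured compounds differ in a single place, so no step between measured compounds can be set against the change considered next.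

Compound 4 `O=C1NC(=O)c2c1c1c3ccc(Br)cc3[nH]c1c1c2c2cccc3c2n1CC(CO)C3` has not yet been measured in this assay. Relative to compound 1 the change is bromo in place of methoxy on an aromatic carbon. Within the data shown here, nothing among the measured compounds tests this exchange on its own. The expectation for compound 4 is a moderate step downward from compound 1 in this assay, a 2.0-fold lower number from compound 1 to compound 4 (0.29 log units; within the scatter), though a result within the scatter would not be surprising. The estimate for compound 4 is 250 ug/mL, with a range from 80 ug/mL to 800 ug/mL.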

Compound 4, solubility: 830 ug/mL
Beside the measured number, compound 4's estimate is 3.3-fold (0.52 log units) below it, and the stated range ends below it.
By their numbers in this assay, from the lowest: compounds 1, 4 and 2 (each within the scatter of the next, the first and the last beyond it); then compound 3.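

In this assay, within the data shown here, the exchange of methoxy for bromo on this aromatic carbon gives a 1.7-fold higher number from compound 1 to compound 4 (0.23 log units; within the scatter) as the first single-place step. At this place, meta to a fused ring and para to a fused ring, the two groups therefore cannot be separated in this read-out, even though methoxy brings one hydrogen-bond acceptor and bromo brings none. No measurement bears on the reason for this result.

Still open, as far as these compounds go, is whether an amine or a carboxylic acid on the same aromatic carbon would give a step beyond the scatter. Also open, from the compounds shown here alone, is whether the exchange of methoxy for bromo would give a step of similar size on the other cores.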